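Replacing Chloro with Trifluoromethyl on Compound 2

The compounds below may be only part of what the source reports. "The series", "measured", "known", "first", "only" and "open" are said of these compounds alone.

Of the compounds shown here, two have so far been measured in a functional assay on Bel-7402 cells (Homo sapiens) for inhibition, read by MTT assay, with a stated time of 24 h, tested at 100 ug/mL (on this read-out higher numbers stand for more inhibition of growth at the one concentration tested and lower numbers for less inhibition of growth), and they lie well apart. There compound 1 (`O=C(CCCCC1CCSS1)Nc1cccc(C(F)(F)F)c1`) gives 61.9% of inhibition, and compound 2 (`O=C(CCCCC(S)CCS)Nc1cccc(Cl)c1`) gives 16.1% of inhibition, which places compound 2 lower of the pair by a gap beyond the scatter.

The next structure is compound 3 (`O=C(CCCCC(S)CCS)Nc1cccc(C(F)(F)F)c1`). It departs from compound 2 in one place, summed up by trifluoromethyl in place of chloro on an aromatic carbon as trifluoromethyl in place of chloro on an aromatic carbon. Within the data shown here, no measured pair yet isolates this kind of change. Compound 3 shares its trifluoromethyl with compound 1, but the two differ elsewhere in the structure, and compounds 1 and 2 differ in more than one place. The gap between them therefore cannot be credited to the aromatic group alone.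

A modest rise in this assay is expected, with an estimated a number 7.9 percentage points higher from compound 2 to compound 3 (within the scatter) that stays within the scatter. Compound 3 is estimated at 24% within an expected range from 10% to 48% on the same read-out.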

Compound 3, percent growth inhibition at one concentration: 25.3%
The estimate for compound 3 lay 1.3 percentage points below the measured number; measured number inside the range.
By their numbers in this assay, from the lowest: compounds 2 and 3 (each within the scatter of the next); then compound 1.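

In this assay, trifluoromethyl in place of chloro on an aromatic carbon, meta to a large group, gives a number 9.2 percentage points higher from compound 2 to compound 3 (within the scatter), so on the open-chain compounds this exchange of groups cannot be told from the usual scatter of repeats. Among these compounds, compound 3 also gives the first single-place comparison with compound 1: with trifluoromethyl held on both, the open group of 3 carbon and 2 sulfur atoms in place of the one five-membered non-aromatic ring with 2 hetero atoms gives a number 36.6 percentage points lower from compound 1 to compound 3 (beyond the scatter), a large step beyond the scatter. Among the compounds shown here, of the two single changes now readable, only the one on the saturated chain carbon separates two compounds, and nothing available explains either step.

The compounds shown leave open whether the exchange of chloro and trifluoromethyl would stay as small if the five-membered ring were present, since the aromatic group has been varied only on the open-chain compounds. They also leave open how other groups on that aromatic carbon, such as an amine or a nitrile, or a longer chain leading to the sulfur-bearing end, would read in this assay at the one concentration tested.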